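A few compounds are considered here, and "the series" means these few. Any claim that something is new, unique, unknown or untested is made for them only; others in the source may bear on it.

Compound 1 `O=S(=O)(Nc1ccc(-c2nc3ccccc3o2)cc1)c1ccccc1Cl` is one of three closely related sulfonamides examined in an assay on isolated protein for inhibition of malate dehydrogenase, mitochondrial (Sus scrofa), with stated times of 45 min and 30 min; on this read-out lower numbers stand for stronger inhibition and higher numbers for weaker inhibition. For compound 1 the result is only a limit of the assay, > 63000 nM, so no number is available for it. Compound 2 `O=S(=O)(Nc1ccc2oc(-c3ccccc3)nc2c1)c1cccc(F)c1` likewise returns only a limit, > 63000 nM. Compound 3 `O=S(=O)(Nc1ccc2oc(-c3ccccc3)nc2c1)c1ccc(F)c(C(F)(F)F)c1` also returns only a limit, > 63000 nM. Across this small set every measurement therefore sits at the same boundary, as summarised by the limit of > 63000 nM in this assay, at which 3 of the 3 values shown sit, and no step between any two of these compounds can be measured.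

The untested compound 4 `O=S(=O)(Nc1ccc(-c2nc3ccccc3o2)cc1)c1ccc(Cl)cc1` differs from compound 1 in a single place: 4-chlorophenyl in place of 2-chlorophenyl on a sulfonyl sulfur. Among the compounds with values here, since both compounds 1, 2 and 3 give only limits in this assay, there is no measured step from which the effect of such a change could be read, and nothing among the three compounds points to a gain in inhibition.

It is expected that the step from compound 1 to compound 4, a step that the limit leaves unreadable from compound 1 to compound 4, will be none beyond the scatter, with the result most likely again only a limit. Compound 4 is accordingly estimated at 80000 nM, with a range from 30000 nM to 250000 nM.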

Compound 4, half-maximal inhibitory concentration: > 63000 nM
Compound 4: no number, only a limit (the forecaster's own chance of this, stated with the estimate: 85%); the middle value lies beyond the limit too.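

Compound 1 and compound 4 both return only a limit in this assay, so no step between them can be read, and the exchange of 2-chlorophenyl for 4-chlorophenyl shows no readable effect: the limit of > 63000 nM in this assay, at which 4 of the 4 values shown sit.

The compounds shown leave open whether any of them inhibits the enzyme measurably, and whether 2-chlorophenyl and 4-chlorophenyl differ at all in this respect.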